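Working notes: from compound 3 to compound 4

The compounds below may be only part of what the source reports. "The series", "measured", "known", "first", "only" and "open" are said of these compounds alone.

Values so far in a functional assay on LNCaP cells (Homo sapiens) for antiproliferative activity, read by propidium iodide staining, with a stated time of 96 h (a lower number here means a stronger inhibitor, a higher number a weaker inhibitor), are:
- compound 1 `CC(O)(CSc1ccc(S(F)(F)(F)(F)F)cc1)C(=O)Nc1ccc(C#N)cc1C(F)(F)F` gives 15100 nM
- compound 2 `CC(O)(CSc1ccc(S(F)(F)(F)(F)F)cc1)C(=O)Nc1ccc(S(F)(F)(F)(F)F)cc1` gives 18300 nM
- compound 3 `CC(O)(CSc1ccc(C(F)(F)F)cc1)C(=O)Nc1ccc(S(F)(F)(F)(F)F)cc1` gives 17000 nM

In this assay compound 3 at 17000 nM sits within the scatter of both other compounds, so it holds no distinct rank among the three. All three are weak in absolute terms on this read-out.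

Compound 4 `CC(O)(CSc1ccccc1C(F)(F)F)C(=O)Nc1ccc(S(F)(F)(F)(F)F)cc1` has not yet been measured. It carries 2-(trifluoromethyl)phenyl in place of 4-(trifluoromethyl)phenyl on a sulfur and is otherwise the same as compound 3.

Within the data shown here, one measured step bears on this change, and only indirectly. It is a 1.1-fold lower number from compound 2 to compound 3 (0.03 log units; within the scatter) and it stays within the scatter. Among the measured compounds shown here, that step exchanges one group for another on an aromatic carbon, whereas the new change moves a group, and no measurement yet tests such a move. With so flat a set of values, the working expectation is no shift beyond the scatter, held with moderate confidence only. The expected step in this assay is a 1.1-fold lower number from compound 3 to compound 4 (0.03 log units; within the scatter) and direction is left open. For compound 4 the estimate is 16000 nM with 8000 nM to 30000 nM as the expected range.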

Compound 4, half-maximal inhibitory concentration: 12300 nM
The estimate for compound 4 lay 1.3-fold (0.11 log units) above the measured number; low and high end bracket the measured number.
By their numbers in this assay, from the lowest: compounds 4, 1, 3 and 2 (each within the scatter of the next).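

In this assay, among these compounds, 2-(trifluoromethyl)phenyl in place of 4-(trifluoromethyl)phenyl on a sulfur gives a 1.4-fold lower number from compound 3 to compound 4 (0.14 log units; within the scatter); this is the first measured step that keeps the same atoms and joins them differently, rather than exchanging one group for another. Among the compounds shown here, this read-out therefore does not separate the two trifluoromethylphenyl groups on the sulfur, and the series stays flat across both kinds of change, with no compound among the four standing apart from its neighbour in the ranking. No measured information is available that would account for this flat response.

The compounds shown leave open whether any replacement on the sulfur-bound phenyl ring, such as a methoxy group, a carboxylic acid or an amine, would produce a step beyond the scatter. Going by these compounds, it also remains open whether exchanging the sulfur itself for an oxygen atom, or replacing the phenyl ring with a longer saturated chain, would bring the values of this series out of their present narrow band.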